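Replacing the aminophenyl with a pyridyl on the lactam nitrogen

The source may report more compounds than this note shows. Statements on the series, on what has been measured and on what is new or still open speak of the compounds shown alone.

compound 1 `COc1ccc([C@H]2CC(=O)N(c3ccccc3N)C2)cc1OC1CCCC1` in a functional assay on HEK293 cells (Homo sapiens) for cytotoxicity; a higher number here means that more compound is tolerated, a lower number that less compound is tolerated: > 10000 nM, a limit of the assay
compound 2 `COc1ccc([C@H]2CC(=O)N(c3ccc(C(F)(F)F)cc3)C2)cc1OC1CCCC1` in this assay: > 10000 nM, a limit of the assay

Compound 1 stands only at a limit in this assay: its value of > 10000 nM is a limit and not a number. Compound 2 likewise sits at a limit of > 10000 nM. The step that the two limits leave unreadable from compound 1 to compound 2 therefore cannot be read. Compound 3 `COc1ccc([C@H]2CC(=O)N(c3ccccn3)C2)cc1OC1CCCC1` differs from compound 1 as pyridin-2-yl in place of 2-aminophenyl on an amide-type nitrogen in a ring. No measured step bears on this change in a readable way, since both shown values sit at the limit (the limit of > 10000 nM in this assay, at which 2 of the 2 values shown sit). Compound 3 is therefore expected to sit at the limit as well, an estimated 20000 nM (range 8000 nM to 60000 nM), meaning an expected step that the limit leaves unreadable from compound 1 to compound 3, not beyond the scatter.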

Compound 3, half-maximal cytotoxic concentration: > 10000 nM
Compound 3 gave a limit, no number (the forecaster's own chance of this, stated with the estimate: 80%); the middle value lies beyond the limit too.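

Compound 3 also gives only a limit, not a number, so neither step to it, from compound 1 or from compound 2, can be read: the limit of > 10000 nM in this assay, at which 3 of the 3 values shown sit.

The compounds shown leave open whether any group on the amide-type nitrogen changes the concentration tolerated in this assay.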